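Adding a hydroxy group to the acetyl arm of compound 1

This account rests on a few compounds, and the source may have more. Where it says the series, first, only, none or still open, it means among the compounds named here.

Compound 1 `CC(=O)N(O)C(C)c1ccc2oc(-c3ccccc3)cc2c1` is the starting point. In an assay on RBL cells for inhibition of Polyunsaturated fatty acid 5-lipoxygenase (Rattus norvegicus) (on this read-out higher numbers stand for weaker inhibition and lower numbers for stronger inhibition), compound 1 gives 490 nM, the highest number among the three measured compounds. Compound 2 `CC(c1ccc2oc(-c3ccccc3)cc2c1)N(O)C(=O)c1ccco1` gives 40 nM in this assay, and compound 3 `CC(=O)OCC(=O)N(O)C(C)c1ccc2oc(-c3ccccc3)cc2c1` gives 160 nM in this assay. The two measured steps from compound 1 were a 12-fold lower number from compound 1 to compound 2 (1.09 log units; beyond the scatter) and a 3.1-fold lower number from compound 1 to compound 3 (0.49 log units; beyond the scatter), so both changes at the carbonyl side of compound 1 moved the number well downward.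

Compound 4 `CC(c1ccc2oc(-c3ccccc3)cc2c1)N(O)C(=O)CO` differs from compound 1 by a single small change: hydroxy in place of hydrogen on a saturated chain carbon bound to a carbonyl carbon. Among the measured compounds shown here, the step that bears most directly on this change is the one to compound 3, where a related oxygen-bearing group, acetoxy, entered the same saturated chain carbon and gave a 3.1-fold lower number from compound 1 to compound 3 (0.49 log units; beyond the scatter). For the measured compounds named here, that step was modest but beyond the scatter, so a change in the same direction is expected for compound 4, though no measured pair shows exactly a hydroxy at this place, and the size is therefore uncertain.

For compound 4 a value of 200 nM in this assay is expected, likely between 80 nM and 500 nM, corresponding to an estimated step of a 2.5-fold lower number from compound 1 to compound 4 (0.39 log units; beyond the scatter).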

Compound 4, half-maximal inhibitory concentration: 700 nM
The estimate for compound 4 lay 3.5-fold (0.54 log units) below the measured number; the measured number lies above the stated range.
By their numbers in this assay, from the lowest: compound 2; then compound 3; then compounds 1 and 4 (each within the scatter of the next).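

In this assay, putting a hydroxy group on the saturated chain carbon bound to the carbonyl carbon leaves compound 4 level with compound 1, the step being a 1.4-fold higher number from compound 1 to compound 4 (0.15 log units; within the scatter). The gain seen with acetoxy on this same carbon therefore does not carry over to the free hydroxy group, as the step with the acetyl removed shows, a 4.4-fold higher number from compound 3 to compound 4 (0.64 log units; beyond the scatter), and hydroxymethyl on the carbonyl carbon also stands far from furan-2-yl there, at an 18-fold higher number from compound 2 to compound 4 (1.24 log units; beyond the scatter). Nothing at hand gives a reason why acetoxy and hydroxy differ at this place.

From the compounds shown here alone, it remains open whether a methoxy group, an amine or a longer chain such as hydroxyethyl on this carbon would behave like hydroxy or like acetoxy. Going by these compounds, it is also open whether another ring on the carbonyl carbon, such as thiophen-2-yl or phenyl, could match compound 2 at 40 nM.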